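Chloro for Methyl: What to Expect of Compound 3

The source may hold more compounds than are shown below. What is called first, only, known or untested is meant among the compounds shown, and "the series" means these compounds.

Compound 2 `CCOC(=O)c1c(-c2ccc(Cl)c(Cl)c2)cc(-c2ccccc2)nc1Nc1ccc(C)cc1` is the lower of the two compounds measured in a functional assay on the whole organism (strain Wister albino) for inhibition, with Rattus norvegicus as the target, read by paw edema, with stated times of 1 h and 24 h, at a dose of 50 mg/kg by the intraperitoneal route (a lower number here means less inhibition, a higher number more inhibition at the dose given (going by the name of the read-out)), where compound 2 gives 40.8%. For the measured compounds named here, compound 1 `CCOC(=O)c1c(-c2ccc(Cl)cc2)cc(-c2ccccc2)nc1Nc1ccc(C)cc1` gives 62.7% in this assay, and the only measured step, a number 21.9 percentage points lower from compound 1 to compound 2 (beyond the scatter), is modest. Compound 3 `CCOC(=O)c1c(-c2ccc(Cl)c(Cl)c2)cc(-c2ccccc2)nc1Nc1ccc(Cl)cc1` differs from compound 2 by chloro in place of methyl on an aromatic carbon, on an aromatic carbon para to a large group. Going by the values given here, no measured step swaps methyl for chloro, so nothing bears directly on this change. Compound 3 is therefore expected to hold roughly the level already seen in this assay, a step of a number 0.8 percentage points lower from compound 2 to compound 3 (within the scatter) within the scatter, at an estimated 40% with a range from 25% to 55%.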

Compound 3, a percentage reported as inhibition, in the whole organism at one dose (the size of the read-out at that dose, not a potency): 52.7%
Compound 3: the middle estimate sits 12.7 percentage points below what was measured, within the range that was stated.
By their numbers in this assay, from the lowest: compound 2; then compounds 3 and 1 (each within the scatter of the next).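

In this assay, for the compounds shown here, the swap from (4-methylphenyl)amino to (4-chlorophenyl)amino gives a number 11.9 percentage points higher from compound 2 to compound 3 (beyond the scatter), showing that the read-out responds to this position, which no earlier step had touched. Going by these compounds alone, the only earlier step, a number 21.9 percentage points lower from compound 1 to compound 2 (beyond the scatter), came from a chloro entering elsewhere on the shared core, so a chloro can accompany a number moving either way in this small set. Nothing shown explains this step. On these data alone, it remains open whether an amine or a methoxy group here would raise the number further, and whether the same swap would give a similar step on compound 1.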